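The source may report more compounds than this note shows. Statements on the series, on what has been measured and on what is new or still open speak of the compounds shown alone.

Measured compounds, with their values in an assay on LtK cells with ATP-sensitive inward rectifier potassium channel 11 (Homo sapiens) as the target; a higher number here means that more compound is needed for the effect, a lower number that less compound is needed:

- compound 1, `O=C(Nc1c(C(O)(C(F)(F)F)C(F)(F)F)ccc2ccccc12)c1ccccc1Cl`: 2040 nM
- compound 2, `O=C(Nc1c(C(O)(C(F)(F)F)C(F)(F)F)ccc2ccccc12)c1ccc(F)cc1`: 70 nM
- compound 3, `COc1ccc(C(=O)Nc2c(C(O)(C(F)(F)F)C(F)(F)F)ccc3ccccc23)cc1`: 417 nM

Compound 3 stands second highest of the three numbers in this assay. Its nearest neighbour is compound 1, from which the step of a 4.9-fold lower number from compound 1 to compound 3 (0.69 log units; beyond the scatter) leads down to compound 3; its furthest is compound 2, reached by the step of a 6.0-fold higher number from compound 2 to compound 3 (0.78 log units; beyond the scatter), both beyond the scatter. The largest change seen among these three is a 29-fold lower number from compound 1 to compound 2 (1.46 log units; beyond the scatter).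

Compound 4, `O=C(Nc1c(C(O)(C(F)(F)F)C(F)(F)F)ccc2ccccc12)c1cnco1`, differs from compound 3 in one place: 1,3-oxazol-5-yl in place of 4-methoxyphenyl on a carbonyl carbon. The measured steps that bear on this are those that alter the group on the carbonyl carbon, namely a 4.9-fold lower number from compound 1 to compound 3 (0.69 log units; beyond the scatter) and a 6.0-fold higher number from compound 2 to compound 3 (0.78 log units; beyond the scatter), both of modest size; the large step of a 29-fold lower number from compound 1 to compound 2 (1.46 log units; beyond the scatter) shows how far such changes can reach. Within the data shown here, none of the measured steps exchanges a six-membered aromatic ring of carbon only for a five-membered aromatic ring with two hetero atoms, so the direction is not anchored by a direct precedent. A modest step in this assay is therefore expected, with a wide range, and the estimate for compound 4 means a step of a 1.9-fold higher number from compound 3 to compound 4 (0.28 log units; within the scatter). Compound 4 is thus expected to give about 800 nM, between 150 nM and 5000 nM.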

Compound 4, half-maximal effective concentration: 24 nM
Beside the measured number, compound 4's estimate is 33-fold (1.52 log units) above it; the whole stated range lies above it.
By their numbers in this assay, from the lowest: compound 4; then compound 2; then compound 3; then compound 1.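

In this assay, the group on the carbonyl carbon need not be a six-membered aromatic ring of carbon only: the change from 4-methoxyphenyl to 1,3-oxazol-5-yl, a smaller ring with 5 heavy atoms in place of 8 and with 2 hetero atoms, gives a large step (a 17-fold lower number from compound 3 to compound 4 (1.24 log units; beyond the scatter)). The new ring also goes beyond the best phenyl group shown (a 2.9-fold lower number from compound 2 to compound 4 (0.46 log units; beyond the scatter)) and far beyond the 2-chlorophenyl group (an 85-fold lower number from compound 1 to compound 4 (1.93 log units; beyond the scatter)), so compound 4 now has the lowest number of the four, with all its steps beyond the scatter, and the span of this single position has widened. Nothing available here explains why this exchange lowers the number.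

On these data alone, whether the result belongs to the 1,3-oxazol-5-yl ring in particular remains open, as a furan-2-yl, a 1,3-thiazol-5-yl or a pyridin-3-yl group on the same carbonyl carbon would be needed to separate ring size from the kind and placing of the hetero atoms. As far as these compounds go, it is equally open how this position responds to a saturated ring such as piperidine, or to an amine or a carboxylic acid carried on the oxazole ring.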